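Changing the amine tail of compound 2

The source may hold more compounds than are shown below. What is called first, only, known or untested is meant among the compounds shown, and "the series" means these compounds.

Among the measured compounds shown here, compound 2 `COc1cc2c(Nc3ccc(C#N)cc3)ncnc2cc1OCCCN1CCC(N2CCCCC2)CC1` gives the lower of the two numbers recorded in a functional assay on DU-145 cells (Homo sapiens) for antiproliferative activity, read by MTT assay, with a stated time of 72 h (on this read-out lower numbers stand for stronger inhibition and higher numbers for weaker inhibition), at 15600 nM; compound 1 `COc1cc2c(Nc3ccc(C#N)cc3)ncnc2cc1OCCCN1CCC(O)CC1` gives 74900 nM, and the single measured step, a 4.8-fold lower number from compound 1 to compound 2 (0.68 log units; beyond the scatter), separates them. Compound 3 `COc1cc2c(Nc3ccc(C#N)cc3)ncnc2cc1OCCCN1CCN(c2ccncc2)CC1` differs from compound 2 in one place: 4-(pyridin-4-yl)piperazin-1-yl in place of 4-(piperidin-1-yl)piperidin-1-yl on a saturated chain carbon, three bonds along the chain from an oxygen on an aromatic ring. For the measured compounds named here, no measured step tests this exchange, so only the one known step offers a scale, and the change is therefore expected to bring a modest shift toward a higher number, a 1.8-fold higher number from compound 2 to compound 3 (0.25 log units; within the scatter). Compound 3 is estimated at 28000 nM, with a range from 8000 nM to 90000 nM.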

Compound 3, half-maximal inhibitory concentration: 22900 nM
Compound 3: middle estimate off by 1.2-fold (0.09 log units), on the high side; measured number inside the range.
By their numbers in this assay, from the lowest: compounds 2 and 3 (each within the scatter of the next); then compound 1.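

In this assay, 4-(pyridin-4-yl)piperazin-1-yl in place of 4-(piperidin-1-yl)piperidin-1-yl gives a 1.5-fold higher number from compound 2 to compound 3 (0.17 log units; within the scatter), so at this position the two tails cannot be told apart, although the entering one carries an aromatic ring. The step of a 3.3-fold lower number from compound 1 to compound 3 (0.51 log units; beyond the scatter) shows that a second tail, also replacing 4-hydroxypiperidin-1-yl, stands apart from compound 1 in the same direction as the first. Nothing available explains these numbers. Going by these compounds, whether a morpholine or an open-chain dimethylamino group at this position would group with compound 2 and compound 3 remains open, as does the effect of a longer chain carrying these tails.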